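A few compounds are considered here, and "the series" means these few. Any claim that something is new, unique, unknown or untested is made for them only; others in the source may bear on it.

Measured so far:
- compound 1, `CCN1CCN(c2cc(C)c3cc(NC(=O)c4ccc(Cl)cc4)ccc3n2)CC1`: 1530 nM
- compound 2, `Cc1cc(N2CCCCC2)nc2ccc(NC(=O)c3ccc(Cl)c(Cl)c3)cc12`: 31100 nM

Two compounds of this series have numbers in a functional assay on MCF7 cells (Homo sapiens) for antiproliferative activity, read by MTT assay, with a stated time of 72 h; a higher number here means a weaker inhibitor, a lower number a stronger inhibitor. Among the measured compounds shown here, compound 1 has the lower of the two, and compound 2 sits a long way higher; the two differ in more than one place, so nothing can be said of a single change between them, only that compound 1 gives the stronger result and the gap between the two values lies beyond the usual scatter.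

Compound 3, `CCN1CCN(c2cc(C)c3cc(NC(=O)c4cc5ccccc5[nH]4)ccc3n2)CC1`, is not yet measured. Relative to compound 1 the difference is 1H-indol-2-yl in place of 4-chlorophenyl on a carbonyl carbon. The amide linkage and the shared core are kept; only the group on the carbonyl carbon changes. Nothing in the measured pair bears on this exchange, so the size of the step is an open question. The expectation is a small step toward a higher number, close to the edge of the scatter, rather than a large loss. For compound 3 the estimate is 2500 nM, with a range from 600 nM to 10000 nM, meaning an expected step of a 1.6-fold higher number from compound 1 to compound 3 (0.21 log units; within the scatter).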

Compound 3, half-maximal inhibitory concentration: 2950 nM
Compound 3: middle estimate off by 1.2-fold (0.07 log units), on the low side, within the range that was stated.
By their numbers in this assay, from the lowest: compounds 1 and 3 (each within the scatter of the next); then compound 2.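

In this assay, 1H-indol-2-yl in place of 4-chlorophenyl on a carbonyl carbon gives a 1.9-fold higher number from compound 1 to compound 3 (0.29 log units; within the scatter), so the two compounds cannot be ordered, and this position takes the two-ring group with its hydrogen-bond donor without a step that stands clear of the scatter. Among the compounds shown here, this is the first reading of a single change, as compound 1 and compound 2 differ in more than one place and offer no such reading. No measurement at hand accounts for this result or assigns any part in it to the chlorine, the added ring or the indole hydrogen.

This one exchange changes the ring system, removes the chlorine and adds the donor together, so the compounds shown do not separate these features from one another. On these data alone, it remains open how an unsubstituted phenyl, a 1-methyl-1H-indol-2-yl, a benzofuran-2-yl or a saturated chain such as cyclohexyl would read on the same carbonyl carbon, and whether any of them would stand clear of the scatter from compound 1.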